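Ester to amide on the aryltriazene series

This account rests on a few compounds, and the source may have more. Where it says the series, first, only, none or still open, it means among the compounds named here.

Three aryltriazenes have numbers in a functional assay on L1210 cells (Mus musculus) for antiproliferative activity; on this read-out higher numbers stand for higher potency (the scale is a negative logarithm) and lower numbers for lower potency. Compound 1 `COC(=O)c1cccc(/N=N/N(C)C)c1` gives 3.42 in this assay. Compound 2 `COc1ccc(/N=N/N(C)C(=O)c2ccccc2)cc1` gives 3.05 in this assay, and compound 3 `CCOC(=O)c1ccc(/N=N/N(C)CC(C)C)cc1` gives 2.8 in this assay. Compound 1 therefore stands highest of the three. The gap between compound 1 and compound 2 lies beyond the scatter, and the wider gap between compound 1 and compound 3 lies beyond the scatter as well. Going by the values given here, none of these three pairs differs in a single place, so no clean step is available within the measured set.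

Compound 4 `CN(C)/N=N/c1cccc(C(N)=O)c1` is the next member, not yet measured in this assay. It differs from compound 1 in one place: amino in place of methoxy on a carbonyl carbon. Cut one bond further out, the change reads methoxycarbonyl to carbamoyl on the core of compound 1. Among the compounds with values here, with no measured single-place step to lean on, the expected step from compound 1 to compound 4, a number 0.12 log units lower from compound 1 to compound 4 (within the scatter), is small and not clearly beyond the scatter in either direction. Compound 4 is accordingly expected to give about 3.3 in this assay, within a range of 2.9 to 3.7.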

Compound 4, logarithm of the reciprocal of the active concentration, log(1/C): 3.8
Estimate against measurement, compound 4: 0.50 log units below; measured number above the stated range.
By their numbers in this assay, from the lowest: compounds 3 and 2 (each within the scatter of the next); then compound 1; then compound 4.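

The series now has its first single-place step: in this assay, amino in place of methoxy on a carbonyl carbon gives a number 0.38 log units higher from compound 1 to compound 4 (beyond the scatter) as a modest change beyond the scatter. Going by these compounds alone, on the core of compound 1, the carbonyl carbon therefore accepts carbamoyl in place of methoxycarbonyl with no loss on this read-out, which the earlier compounds, differing in more than one place, could not show. No measurement here bears on the reason for this step.

Going by these compounds, how far the step depends on the amino group itself remains open, as a carboxylic acid or a dimethylamino group on the same carbonyl carbon would have to show. On these data alone, it also rests on one pair, so whether the same change gives a similar step on the other cores remains unknown.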